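The compounds below may be only part of what the source reports. "The series", "measured", "known", "first", "only" and "open" are said of these compounds alone.

Measured so far:
- compound 1 `CCOC(=O)c1ccc(Nc2nnc(Cl)c(Nc3cc(OC)c(OC)c(OC)c3)n2)cc1`: 58500 nM
- compound 2 `COc1cccc(Nc2nnc(Cl)c(Nc3cc(OC)c(OC)c(OC)c3)n2)c1`: 11300 nM
- compound 3 `COc1cc(Nc2nc(Nc3ccc(C)cc3)nnc2Cl)cc(OC)c1OC`: 14300 nM

In a functional assay on PC-3 cells (Homo sapiens) for inhibition, read by MTT assay, with a stated time of 48 h (on this read-out lower numbers stand for stronger inhibition and higher numbers for weaker inhibition), compound 3 holds the second highest of the three numbers. The gap to its nearest neighbour is a 1.3-fold higher number from compound 2 to compound 3 (0.10 log units; within the scatter), and the gap to the furthest is a 4.1-fold lower number from compound 1 to compound 3 (0.61 log units; beyond the scatter).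

Compound 4 `COc1cc(Nc2nc(Nc3ccc(Br)cc3)nnc2Cl)cc(OC)c1OC` has bromo in place of methyl on an aromatic carbon, para to a large group: bromo in place of methyl on an aromatic carbon.

The step at this same place, ethoxycarbonyl to methyl, was modest. The change of aryl group stayed within the scatter. Going by the values given here, no measured compound carries bromo, so this assay is expected to show no step beyond the scatter. The estimated step is a 1.2-fold lower number from compound 3 to compound 4 (0.09 log units; within the scatter). Compound 4 is expected at 11500 nM, within an estimated range of 5500 nM to 24000 nM.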

Compound 4, half-maximal inhibitory concentration: 8990 nM
For compound 4 the middle estimate is 1.3-fold (0.11 log units) above the measured one; the measured number falls inside the stated range.
By their numbers in this assay, from the lowest: compounds 4, 2 and 3 (each within the scatter of the next); then compound 1.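

In this assay, bromo in place of methyl on this aromatic carbon, para to a large group, gives a 1.6-fold lower number from compound 3 to compound 4 (0.20 log units; within the scatter) and so does not separate the two groups. The change of aryl group, a 1.3-fold lower number from compound 2 to compound 4 (0.10 log units; within the scatter), also leaves compound 4 unseparated from compound 2. Bromo in place of ethoxycarbonyl gives a 6.5-fold lower number from compound 1 to compound 4 (0.81 log units; beyond the scatter) and so runs the same way as methyl in place of ethoxycarbonyl, with no measured evidence bearing on the cause of these steps.

Going by these compounds, whether an amine or a carboxylic acid at this position would separate from bromo and methyl stays open.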